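The source may hold more compounds than are shown below. What is called first, only, known or untested is meant among the compounds shown, and "the series" means these compounds.

Compound 1 `O=C(COc1ccc(C(=O)/C=C/c2ccc(Cl)cc2Cl)cc1)N[C@H]1CCOC1=O`: 8040 nM
Compound 2 `CC(C)c1ccc(/C=C/C(=O)c2ccc(OCC(=O)N[C@H]3CCOC3=O)cc2)cc1`: 4660 nM
Compound 3 `O=C1OCC[C@@H]1NC(=S)SCCOc1ccc(Cl)cc1`: only a limit of the assay, > 64000 nM

These three compounds were tested in a functional assay on PC-3 cells (Homo sapiens) for antiproliferative activity, read by MTT assay, with a stated time of 72 h; on this read-out higher numbers stand for weaker inhibition and lower numbers for stronger inhibition. Compound 2 and compound 1 share the same core and differ only in the aryl group on the double-bonded chain; their numbers lie within the scatter of each other, as a 1.7-fold lower number from compound 1 to compound 2 (0.24 log units; within the scatter) shows. Compound 3, built on a different core, reaches only a limit of > 64000 nM in this assay, at which 1 of the 3 values shown sits, and gives no number to compare.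

The next compound, compound 4 `O=C(COc1ccc(C(=O)/C=C/c2ccc(Br)cc2)cc1)N[C@H]1CCOC1=O`, again keeps the core of compound 2 and changes only the aryl group: bromo in place of isopropyl on an aromatic carbon. Among the compounds with values here, the one measured step that bears on this, from compound 1 to compound 2, swapped groups at the same aryl position and stayed within the scatter. A change of the same kind is therefore expected to move the number little, if at all, and the step from compound 2 to compound 4 is estimated at a 1.3-fold higher number from compound 2 to compound 4 (0.11 log units; within the scatter). Compound 4 is accordingly expected to give about 6000 nM, within a range from 2500 nM to 15000 nM.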

Compound 4, half-maximal inhibitory concentration: > 64000 nM
Compound 4: only a limit was reported; the forecaster's own chance of this, stated with the estimate: 5%; middle value at least 10-fold (1.02 log units) from the limit.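

The aryl group on the shared core turns out to matter far more than the earlier swap suggested, since that swap stayed within the scatter: bromo in place of isopropyl gives an at least 13-fold higher number from compound 2 to compound 4 (1.13 log units; beyond the scatter), and 4-bromophenyl in place of 2,4-dichlorophenyl gives an at least 7.9-fold higher number from compound 1 to compound 4 (0.90 log units; beyond the scatter). Carrying a halogen on this ring does not by itself decide the outcome, as compound 1, with its 2,4-dichlorophenyl group, still gives a measured number. Compound 4 gives only a limit of the assay, so these steps set a minimum size and not an exact one: the limit of > 64000 nM in this assay, at which 2 of the 4 values shown sit.

The compounds shown leave open how far the number would rise if compound 4 could be measured exactly. They also leave open whether 4-chlorophenyl, 4-methylphenyl or 4-methoxyphenyl would behave like 4-bromophenyl or like 4-isopropylphenyl.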